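Swapping the aryl group on the isoxazole arm

The source may hold more compounds than are shown below. What is called first, only, known or untested is meant among the compounds shown, and "the series" means these compounds.

Measured compounds:
compound 1, `COc1ccc2nc(N(Cc3cc(-c4ccc(Br)cc4)no3)c3nc4ccc(F)cc4s3)sc2c1`, 32700 nM
compound 2, `C#CCN(c1ncccn1)c1nc2ccccc2s1`, 17400 nM
compound 3, `FC(F)(F)Sc1ccc(-c2cc(CN(c3ncccn3)c3nc4ccccc4s3)on2)cc1`, 29800 nM

In a functional assay on A549 cells (Homo sapiens) for antiproliferative activity, read by MTT assay (a higher number here means a weaker inhibitor, a lower number a stronger inhibitor), compound 3 gives 29800 nM. That number stands between the values of compound 1 and compound 2, and both of those lie within the usual scatter of it, so the three measured compounds cannot be told apart on this assay; all three are weak inhibitors.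

Compound 4, `Fc1ccccc1-c1cc(CN(c2ncccn2)c2nc3ccccc3s2)on1`, is not yet measured. It differs from compound 3 in one place: 2-fluorophenyl in place of 4-((trifluoromethyl)sulfanyl)phenyl on an aromatic carbon. Within the data shown here, no pair of measured compounds differs in only one place, so there is no measured step to lean on, and the three known values give no sign that changes on this arm move the number beyond the scatter. The expectation for compound 4 is therefore a step of a 1.0-fold higher number from compound 3 to compound 4 (0.00 log units; within the scatter), no larger than the scatter, in no particular direction. Compound 4 is estimated at 30000 nM in this assay, with a range from 12000 nM to 75000 nM.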

Compound 4, half-maximal inhibitory concentration: 25400 nM
Compound 4: middle estimate off by 1.2-fold (0.07 log units), on the high side, within the range that was stated.
By their numbers in this assay, from the lowest: compounds 2, 4, 3 and 1 (each within the scatter of the next).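

Among these compounds, compound 3 and compound 4 form the first measured pair that differs in one place only, so the aryl group on the carbon next to the ring nitrogen can now be judged directly. In this assay, exchanging 4-((trifluoromethyl)sulfanyl)phenyl, with 11 heavy atoms and 1 hydrogen-bond acceptor, for 2-fluorophenyl, with 7 heavy atoms and no acceptor, gives a 1.2-fold lower number from compound 3 to compound 4 (0.07 log units; within the scatter), so for these two aryl groups the position shows no measurable response. No supporting measurement is available to explain this result.

This single pair cannot show whether the position tolerates groups other than substituted phenyl rings. An amine, a carboxylic acid or a longer alkyl chain at this carbon might still move the number beyond the scatter.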